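Extending the chain of compound 3

The compounds below may be only part of what the source reports. "The series", "measured", "known", "first", "only" and "open" are said of these compounds alone.

Among the measured compounds shown here, in a functional assay on MCF7 cells (Homo sapiens) for antiproliferative activity, read by MTT assay, with a stated time of 72 h (on this read-out higher numbers stand for weaker inhibition and lower numbers for stronger inhibition), compound 3 (`CCCCCCCCCCCCNC[C@@H]1OC[C@H](N)[C@H]1O`) gives 12600 nM as the lowest number so far, and compound 1 (`CCCCCCCCCCNC[C@@H]1OC[C@H](N)[C@@H]1O`) gives 34200 nM as the only other number. Compound 2 (`CCCCCCCNC[C@@H]1OC[C@H](N)[C@@H]1O`) stands at the limit of > 128000 nM and gives no number. Compound 4 (`CCCCCCCCCCCCCCNC[C@@H]1OC[C@H](N)[C@H]1O`) follows from compound 3 by ethyl in place of hydrogen on a saturated chain carbon, ten or more bonds along the chain from an amine nitrogen and keeps its core, whose stereochemistry differs from that of compound 1. For the measured compounds named here, the one measured step on chain length is hydrogen in place of propyl (an at least 3.7-fold higher number from compound 1 to compound 2 (0.57 log units; beyond the scatter)), which runs the opposite way and ends at a limit. Only a small further fall is therefore expected in this assay, and the expected change (a 1.6-fold lower number from compound 3 to compound 4 (0.20 log units; within the scatter)) stays within the scatter. Compound 4 is estimated at 8000 nM (range 3000 nM to 22000 nM).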

Compound 4, half-maximal inhibitory concentration: 8830 nM
Compound 4: the middle estimate sits 1.1-fold (0.04 log units) below what was measured, within the range that was stated.
By their numbers in this assay, from the lowest: compounds 4 and 3 (each within the scatter of the next); then compound 1. At a limit, above all of these: compound 2.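

In this assay, ethyl in place of hydrogen on a saturated chain carbon gives a 1.4-fold lower number from compound 3 to compound 4 (0.15 log units; within the scatter), so this change leaves the number unmoved beyond the scatter. Among the compounds shown here, the one earlier chain step, on the core of compound 1 and at another place, lay beyond the scatter, so that result does not carry over to this place on the core of compound 3. Nothing measured here accounts for this step.

As far as these compounds go, whether a longer chain on this core moves the number beyond the scatter, or a hydroxyl at the chain end does, remains open. From the compounds shown here alone, how the two cores compare at a single chain length also stays open.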